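Swapping Trifluoromethoxy for Fluoro on a Topoisomerase Inhibitor

The source may report more compounds than this note shows. Statements on the series, on what has been measured and on what is new or still open speak of the compounds shown alone.

Of the compounds shown here, three sharing one core have been tested in an assay on isolated protein for inhibition of DNA topoisomerase 1 (Homo sapiens), with a stated time of 30 min, tested at 100 uM; on this read-out higher numbers stand for a stronger effect at the one concentration tested and lower numbers for a weaker effect. Compound 1 `Cc1ccc2c(=O)[nH]c(-c3ccccc3N(C)C)nc2c1` gives 82.1%, compound 2 `Cc1ccc2c(=O)[nH]c(-c3cccc(OC(F)(F)F)c3)nc2c1` gives 77.2%, and compound 3 `CCN(CC)c1ccc2nc(-c3cccc4ccccc34)[nH]c(=O)c2c1` gives 90.4%. On these numbers compound 2 stands lowest of the three, but its gap to compound 1 lies within the usual scatter of this assay, so the two cannot be told apart; only compound 3 sits clearly higher.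

Compound 4 `Cc1ccc2c(=O)[nH]c(-c3cccc(F)c3)nc2c1` has not yet been measured. It differs from compound 2 in one place: fluoro in place of trifluoromethoxy on an aromatic carbon. A group of five heavy atoms on the side ring gives way to a single fluorine in the same position.

Within the data shown here, no pair of measured compounds differing in one place is available, so there is nothing to say how large a step this swap usually brings. The three measured values all lie fairly close together, which suggests that the core carries most of the effect. For compound 4 the step of a number 5.2 percentage points lower from compound 2 to compound 4 (within the scatter) is therefore expected to be small, and possibly not beyond the scatter. Compound 4 is estimated to give 72%, with a likely range from 58% to 85%.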

Compound 4, a percentage reported as inhibition, at one concentration (the size of the read-out at that concentration, not a potency): 77.5%
Compound 4: middle estimate off by 5.5 percentage points, on the low side; the measured number falls inside the stated range.
By their numbers in this assay, from the lowest: compounds 2, 4, 1 and 3 (each within the scatter of the next, the first and the last beyond it).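

Among these compounds, this is the first comparison between compounds that differ in one place: in this assay putting fluoro in place of trifluoromethoxy on an aromatic carbon gives a number 0.3 percentage points higher from compound 2 to compound 4 (within the scatter) and so leaves compound 2 and compound 4 impossible to tell apart. At this position, meta to a large group, a group of 5 heavy atoms with 1 hydrogen-bond acceptor can thus give way to a single fluorine with no difference that this read-out can detect at its one tested concentration, although such a reading is not a potency and two compounds that read alike here could still differ at lower concentrations. No independent measurement is available to explain why these two compounds read alike.

The compounds shown leave open whether this tolerance extends beyond these two groups, since an amine, a carboxylic acid or a longer chain at the same position could give a clearly different number. They also leave open whether the same swap would read alike on the core of compound 3, which carries different groups from those around compound 2 and compound 4.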